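The source may report more compounds than this note shows. Statements on the series, on what has been measured and on what is new or still open speak of the compounds shown alone.

Measured so far in a functional assay on HepG2 cells (Homo sapiens) for cytotoxicity, read by MTT assay, with a stated time of 72 h; a higher number here means a weaker inhibitor, a lower number a stronger inhibitor:
- compound 1, `COc1ccc(CN2CCC(NC(=O)COc3ccc4c(=O)c(-c5ccccc5)coc4c3)CC2)cc1`: > 20000 nM (a limit of the assay)
- compound 2, `O=C(COc1ccc2c(=O)cc(-c3ccccc3)oc2c1)NC1CCN(Cc2ccccc2)CC1`: 16700 nM
- compound 3, `N#Cc1ccc(CN2CCC(NC(=O)COc3ccc4c(=O)cc(-c5ccccc5)oc4c3)CC2)cc1`: 9300 nM

Compound 3 carries the lowest number of the two that are numbers in this assay; its nearest neighbour is compound 2, and the step of a 1.8-fold lower number from compound 2 to compound 3 (0.25 log units; within the scatter) lies within the scatter, so no order between the two is claimed. The value of compound 1 is a limit of the assay and not a number (the limit of > 20000 nM in this assay, at which 1 of the 3 values shown sits).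

Compound 4, `O=C(COc1ccc2c(=O)cc(-c3ccccc3)oc2c1)NC1CCN(Cc2ccc(C(F)(F)F)cc2)CC1`, differs from compound 3 in one place: trifluoromethyl in place of cyano on an aromatic carbon. The group sits on an aromatic carbon of a six-membered carbon ring, para to a large group; cut one bond further out, the change reads 4-cyanobenzyl to 4-(trifluoromethyl)benzyl.

For the measured compounds named here, only one measured step touches this position, a 1.8-fold lower number from compound 2 to compound 3 (0.25 log units; within the scatter), and it is within the scatter. Going by the values given here, no step from a cyano group to a trifluoromethyl group has been measured. The expectation for this assay is therefore a step of no size beyond the scatter, in either direction: the estimated step of a 1.0-fold lower number from compound 3 to compound 4 (0.01 log units; within the scatter).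

Compound 4 is estimated at 9000 nM, with a range from 3000 nM to 30000 nM.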

Compound 4, half-maximal inhibitory concentration: 7200 nM
Compound 4: middle estimate off by 1.3-fold (0.10 log units), on the high side, within the range that was stated.
By their numbers in this assay, from the lowest: compounds 4, 3 and 2 (each within the scatter of the next, the first and the last beyond it). At a limit, above all of these: compound 1.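

In this assay, for the compounds shown here, this aromatic carbon now carries the first step that clears the scatter: a 2.3-fold lower number from compound 2 to compound 4 (0.37 log units; beyond the scatter), although the size is modest. The nitrile on the same carbon did not clear it, with a 1.8-fold lower number from compound 2 to compound 3 (0.25 log units; within the scatter), and exchanging one group for the other gives a 1.3-fold lower number from compound 3 to compound 4 (0.11 log units; within the scatter), so the series does not separate nitrile from trifluoromethyl at this position, and only the trifluoromethyl step from hydrogen stands beyond the scatter. Nothing shown offers a cause for these steps, and the series gives no measured property of either group that could account for them.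

Whether an amine, a carboxylic acid or a longer chain on this aromatic carbon would give a step of similar size stays open, since the substituents shown here are limited to hydrogen, nitrile and trifluoromethyl. From the compounds shown here alone, compound 1 gives > 20000 nM, a limit of the assay, and what separates it from the other compounds stays open.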